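Amino for chloro on the fused ring of compound 2

The compounds below may be only part of what the source reports. "The series", "measured", "known", "first", "only" and "open" are said of these compounds alone.

Measured compounds in a functional assay on NCI-H522 cells (Homo sapiens) for antiproliferative activity, read by sulforhodamine B assay, with a stated time of 48 h; a higher number here means a weaker inhibitor of growth, a lower number a stronger inhibitor of growth:
- compound 1 `Nc1nn(C(=O)Nc2ccc(Cc3ccccc3)cc2)c2ccccc12`: > 100000 nM
- compound 2 `Nc1nn(C(=O)Nc2ccc(Cc3ccccc3)cc2)c2ccc(Cl)cc12`: > 100000 nM

In this assay compound 1 gives > 100000 nM, which is a limit of the assay and not a number. Compound 2 gives > 100000 nM in this assay, again a limit. The step that the two limits leave unreadable from compound 1 to compound 2 therefore cannot be sized; both values sit at the limit of > 100000 nM in this assay, at which 2 of the 2 values shown sit.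

Compound 3 `Nc1ccc2c(c1)c(N)nn2C(=O)Nc1ccc(Cc2ccccc2)cc1` is the next member. It differs from compound 2 by amino in place of chloro on an aromatic carbon. Within the data shown here, the only measured step is the one from compound 1 to compound 2, and it is unreadable, so no measured step gives a size or a direction for the change from compound 2 to compound 3. With both measured compounds at the limit, the working assumption is that compound 3 also returns a limit rather than a number. The expected step is a number no higher from compound 2 to compound 3 (the limit leaves the size open), within the scatter. Compound 3 is expected at 100000 nM, with a range from 20000 nM to 500000 nM, and most likely reported as a limit.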

Compound 3, concentration for total growth inhibition: 39600 nM
For compound 3 the middle estimate is 2.5-fold (0.40 log units) above the measured one; the measured number falls inside the stated range.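

In this assay, among these compounds, compound 3 gives 39600 nM, the first number rather than a limit of the assay. Amino in place of chloro gives an at least 2.5-fold lower number from compound 2 to compound 3 (0.40 log units; beyond the scatter), and amino in place of hydrogen gives an at least 2.5-fold lower number from compound 1 to compound 3 (0.40 log units; beyond the scatter), so this aromatic carbon is a place where a change of group can bring the read-out down from the limit, which the earlier pair could not show, as its step cannot be read. Both new steps are minimum sizes only, with the other two members of the series still resting on the limit: the limit of > 100000 nM in this assay, at which 2 of the 3 values shown sit.

From the compounds shown here alone, the true size of both steps stays open, as does whether the number belongs to amino alone or would also appear with a hydroxyl, a methylamino or an acetylamino group on the same carbon. Also open, going by these compounds, is whether amino on another carbon of the same six-membered ring would give a number at all, and how far the diphenylmethane-type side of the urea contributes once a number can be read.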